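Series of uracil nucleotides: shortening the phosphate chain

The compounds below may be only part of what the source reports. "The series", "measured", "known", "first", "only" and "open" are said of these compounds alone.

Compound 1 `Cn1c(=O)ccn([C@@H]2O[C@H](COP(=O)(O)OP(=O)(O)OP(=O)(O)O)[C@@H](O)[C@H]2O)c1=O` carries the triphosphate; in an in vitro functional assay on 1321-N1 cells for agonist activity at P2Y purinoceptor 4 (Homo sapiens) (a higher number here means that more compound is needed for the effect, a lower number that less compound is needed), compound 1 gives 2920 nM. Compound 2 `Cn1c(=O)ccn([C@@H]2O[C@H](COP(=O)(O)OP(=O)(O)O)[C@@H](O)[C@H]2O)c1=O` is the diphosphate. In this assay compound 2 reaches only the limit of > 100000 nM, so it stands at a limit rather than a number. The measured step shows an at least 34-fold higher number from compound 1 to compound 2 (1.53 log units; beyond the scatter), which sits at the limit of > 100000 nM in this assay, at which 1 of the 2 values shown sits. Compound 3 `Cn1c(=O)ccn([C@@H]2O[C@H](COP(=O)(O)O)[C@@H](O)[C@H]2O)c1=O` differs from compound 2 by a hydrogen atom in place of a group of 4 heavy atoms (3 oxygen, 1 phosphorus; no ring), on an oxygen. Among the compounds with values here, the one measured step bearing on this change was large and toward a higher number, so for compound 3 a further step that the limit leaves unreadable from compound 2 to compound 3 in this assay is expected, most likely again ending at the limit. Compound 3 is therefore estimated at 300000 nM (range 100000 nM to 1000000 nM).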

Compound 3, half-maximal effective concentration: > 100000 nM
Compound 3: no number, only a limit; the forecaster's own chance of this, stated with the estimate: 90%; the middle value does not contradict the limit.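

Compound 3, the monophosphate, gives > 100000 nM in this assay, which is a limit and not a number. Losing both outer phosphate groups gives an at least 34-fold higher number from compound 1 to compound 3 (1.53 log units; beyond the scatter), so the second removal brings no number back into range, although the step between the two shorter compounds cannot be read. Of the compounds shown, only the triphosphate gives a number: the limit of > 100000 nM in this assay, at which 2 of the 3 values shown sit.

On these data alone, how far compound 2 and compound 3 lie past the limit stays open. So does whether a tetraphosphate, a longer chain, would lower the number relative to compound 1.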